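Cyclohexyl for Fluorobenzyl at the Cytotoxicity Limit

This account rests on a few compounds, and the source may have more. Where it says the series, first, only, none or still open, it means among the compounds named here.

In a functional assay on SV5A8 cells (Homo sapiens) for cytotoxicity (on this read-out higher numbers stand for weaker inhibition and lower numbers for stronger inhibition), compound 1 `Cc1ccc2c(NCc3ccc(NC(=O)C4CCN(Cc5cccc(F)c5)CC4)cc3)nc(N(C)C)nc2c1` reaches only the limit > 4170 nM, so no number stands for it. Compound 2 `Cc1ccc2c(NCc3ccc(NC(=O)C4CCN(Cc5ccccc5)CC4)cc3)nc(N(C)CCN(C)C)nc2c1` likewise gives only the limit > 8830 nM in this assay. Compound 3 `CCN1CCN(c2nc(NCc3ccc(NC(=O)C4CCN(Cc5ccccc5)CC4)cc3)c3ccc(C)cc3n2)CC1` also sits at the limit > 13000 nM. The step that the two limits leave unreadable from compound 2 to compound 3 therefore stays unreadable. Compound 4 `Cc1ccc2c(NCc3ccc(NC(=O)C4CCN(C5CCCCC5)CC4)cc3)nc(N(C)C)nc2c1` differs from compound 1 by cyclohexyl in place of 3-fluorobenzyl on an amine nitrogen in a ring. For the measured compounds named here, none of the measured steps touches this position, and all three values shown are limits, so neither a direction nor a size can be read for this change. Compound 4 is therefore expected to give about 6000 nM, between 2000 nM and 20000 nM. The expected step that the limit leaves unreadable from compound 1 to compound 4 is taken as nothing beyond the scatter, most likely again reported as a limit.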

Compound 4, half-maximal inhibitory concentration: > 8320 nM
Compound 4: only a limit was reported (the forecaster's own chance of this, stated with the estimate: 70%); middle value at least 1.3-fold (0.14 log units) from the limit.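

Compound 1 and compound 4 both stand only as limits in this assay, so the step from 3-fluorobenzyl to cyclohexyl cannot be read. The compounds shown leave open how far any of these structures actually inhibits on this read-out.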